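Fluorinated benzyl variants on the shared core

The source may hold more compounds than are shown below. What is called first, only, known or untested is meant among the compounds shown, and "the series" means these compounds.

Compound 1 `OC[C@H]1O[C@@H](n2cnc3c(NCc4cccc(F)c4)ncnc32)[C@H](O)[C@@H]1O` carries a 3-fluorophenyl on a saturated chain carbon bound to a nitrogen on an aromatic ring; in a functional assay on HL-60 cells (Homo sapiens) for antiproliferative activity, with a stated time of 72 h (a lower number here means a stronger inhibitor, a higher number a weaker inhibitor), compound 1 gives 920 nM. Compound 2 `Cc1ccc(CNc2ncnc3c2ncn3[C@@H]2O[C@H](CO)[C@@H](O)[C@H]2O)cc1` carries 4-methylphenyl at that place. In this assay compound 2 reaches only a limit, > 166000 nM, so no number is known for it. The step of an at least 180-fold higher number from compound 1 to compound 2 (2.25 log units; beyond the scatter) is therefore large and open at its upper end because of the limit of > 166000 nM in this assay, at which 1 of the 2 values shown sits.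

For the measured compounds named here, compound 3 `OC[C@H]1O[C@@H](n2cnc3c(NCc4ccc(F)c(F)c4F)ncnc32)[C@H](O)[C@@H]1O` is to be measured. 2,3,4-trifluorophenyl in place of 4-methylphenyl on a saturated chain carbon bound to a nitrogen on an aromatic ring The one measured step that bears on this change is an at least 180-fold higher number from compound 1 to compound 2 (2.25 log units; beyond the scatter), where a fluorinated ring was exchanged for the methyl ring and the number rose far beyond the scatter. Reversing that direction, the return of a fluorinated ring is expected to bring a large step downward in this assay, an at least 66-fold lower number from compound 2 to compound 3 (1.82 log units; beyond the scatter). Compound 3 is expected near 2500 nM in this assay, with a range from 300 nM to 40000 nM.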

Compound 3, half-maximal inhibitory concentration: 13000 nM
Compound 3: the middle estimate sits 5.2-fold (0.72 log units) below what was measured; low and high end bracket the measured number.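

The step of an at least 12-fold lower number from compound 2 to compound 3 (1.10 log units; beyond the scatter) shows that in this assay the 2,3,4-trifluorophenyl ring gives a lower number than the 4-methylphenyl ring at this place on the saturated chain carbon. The step of a 14-fold higher number from compound 1 to compound 3 (1.15 log units; beyond the scatter) shows that fluorine on the ring does not by itself set the number, since the two fluorinated rings stand well apart and compound 1 remains the strongest of the three. Compound 2 stands only at a limit, so the true size of the step to compound 3 stays open: the limit of > 166000 nM in this assay, at which 1 of the 3 values shown sits.

The compounds shown do not separate the number of fluorines from their places on the ring, nor the kind of group from its place. A 4-fluorophenyl or 3-methylphenyl ring, or a 3-methoxyphenyl ring, at this place would speak to these questions.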